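Aryl swap on the aromatic nitrogen: nitro to amino

The source may hold more compounds than are shown below. What is called first, only, known or untested is meant among the compounds shown, and "the series" means these compounds.

Compound 1 `N#CC1=C(N)Oc2c(c3nc4ccccc4nc3c3ccccc23)C12C(=O)N(Cc1cnnn1-c1ccccc1Cl)c1ccccc12` carries 2-chlorophenyl on an aromatic nitrogen; in a functional assay on HCT-116 cells (Homo sapiens) for antiproliferative activity, read by MTT assay, with a stated time of 48 h (on this read-out lower numbers stand for stronger inhibition and higher numbers for weaker inhibition), compound 1 gives only a limit, > 50000 nM. Compound 2 `N#CC1=C(N)Oc2c(c3nc4ccccc4nc3c3ccccc23)C12C(=O)N(Cc1cnnn1-c1cccc(Cl)c1)c1ccccc12` bears 3-chlorophenyl, and in this assay compound 2 likewise returns a limit, > 50000 nM. Compound 3 `N#CC1=C(N)Oc2c(c3nc4ccccc4nc3c3ccccc23)C12C(=O)N(Cc1cnnn1-c1ccc([N+](=O)[O-])cc1)c1ccccc12` carries 4-nitrophenyl; in this assay compound 3 also stops at a limit, > 50000 nM. The steps a step that the two limits leave unreadable from compound 1 to compound 2, a step that the two limits leave unreadable from compound 1 to compound 3 and a step that the two limits leave unreadable from compound 2 to compound 3 thus cannot be sized, and compound 3 stands with the others at the limit of > 50000 nM in this assay, at which 3 of the 3 values shown sit. Compound 4 `N#CC1=C(N)Oc2c(c3nc4ccccc4nc3c3ccccc23)C12C(=O)N(Cc1cnnn1-c1ccc(N)cc1)c1ccccc12` differs from compound 3 by amino in place of nitro on an aromatic carbon. Among the measured compounds shown here, no measured step is readable, so no change beyond the scatter is expected. The expected step is a step that the limit leaves unreadable from compound 3 to compound 4. Compound 4 is estimated at 60000 nM, between 20000 nM and 200000 nM.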

Compound 4, half-maximal inhibitory concentration: 45200 nM
Compound 4: the middle estimate sits 1.3-fold (0.12 log units) above what was measured; the measured number falls inside the stated range.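

In this assay, among the compounds shown here, compound 4 is the first here to give a number and not a limit, and the readable steps are an at least 1.1-fold lower number from compound 3 to compound 4 (0.04 log units; that floor lies within the scatter), an at least 1.1-fold lower number from compound 2 to compound 4 (0.04 log units; that floor lies within the scatter) and an at least 1.1-fold lower number from compound 1 to compound 4 (0.04 log units; that floor lies within the scatter). From the compounds shown here alone, each floor lies within the scatter, so amino in place of nitro on an aromatic carbon shows no firm gain, and the true size of the step stays unknown. The steps among compound 1, compound 2 and compound 3 cannot be read.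

Going by these compounds, whether a carboxylic acid or a hydroxyl in place of amino would move the number stays open. Most of this set still rests on a limit: the limit of > 50000 nM in this assay, at which 3 of the 4 values shown sit.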